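Taking the fluoro group off compound 1

This account rests on a few compounds, and the source may have more. Where it says the series, first, only, none or still open, it means among the compounds named here.

Compound 1 `CC(=NNC(=S)Nc1ccccc1F)c1ccccn1` gives 5 nM
Compound 2 `C/C(=N\NC(=S)Nc1ccc(I)cc1)c1ccccn1` gives 59 nM

In a functional assay on U-87MG ATCC cells (Homo sapiens) for cytotoxicity, read by MTT assay, with a stated time of 48 h (on this read-out lower numbers stand for stronger inhibition and higher numbers for weaker inhibition), compound 1 holds the lower of the two numbers, and the gap to compound 2 lies beyond the scatter. The next compound to be tested is compound 3 `CC(=NNC(=S)Nc1ccccc1)c1ccccn1`, which keeps the core of compound 1 but has hydrogen in place of fluoro on an aromatic carbon. Among the compounds with values here, no measured pair isolates this change, so there is no direct precedent for its size. Compound 1 at 5 nM and compound 2 at 59 nM both carry a halogen on the aromatic ring, whereas compound 3 carries none. A modest rise in the number is therefore expected, slightly beyond the scatter, with the expected step being a 3.0-fold higher number from compound 1 to compound 3 (0.48 log units; beyond the scatter) (a rough judgement). For compound 3 the estimated value in this assay is 15 nM (4 nM to 60 nM).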

Compound 3, half-maximal inhibitory concentration: 1.4 nM
The estimate for compound 3 lay 11-fold (1.03 log units) above the measured number; measured number outside the range, below it.
By their numbers in this assay, from the lowest: compound 3; then compound 1; then compound 2.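

In this assay, hydrogen in place of fluoro on an aromatic carbon, ortho to a large group, gives a 3.6-fold lower number from compound 1 to compound 3 (0.55 log units; beyond the scatter) as a modest step beyond the scatter. This is the only pair shown that isolates a change at this position, and it shows that the fluoro group is not needed for a low number here: compound 3 reaches 1.4 nM with no halogen on the ring at all. Nothing available explains the direction of this step.

As far as these compounds go, whether a different group at this same position, such as chloro, methoxy or an amine, would give a number lower or higher than that of compound 3 remains open. Also open, from the compounds shown here alone, is whether fluoro elsewhere on the same ring would produce a step of similar direction and size.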